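This account rests on a few compounds, and the source may have more. Where it says the series, first, only, none or still open, it means among the compounds named here.

Of the compounds shown here, two have been tested for their ability to displace a labelled ligand from the human Substance-P receptor on cells. Compound 1 `C[C@@H](OCC1(c2ccccc2)CC(NCc2n[nH]c(O)n2)C1)c1cc(C(F)(F)F)cc(C(F)(F)F)c1` gives 0.5 nM in an assay on CHO cells for displacement of a labelled ligand from Substance-P receptor (Homo sapiens); a higher number here means a weaker inhibitor, a lower number a stronger inhibitor. Compound 2 `C[C@@H](OC[C@]1(c2ccccc2)C[C@@H](N2CCCC2=O)C1)c1cc(C(F)(F)F)cc(C(F)(F)F)c1` gives 0.4 nM in this assay. Of the two numbers that of compound 1 is the higher, but its nearest neighbour is compound 2 and the gap between them lies within the usual scatter, so the two cannot be told apart. Among the measured compounds shown here, no single-point step between measured compounds is available to guide the next one.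

Compound 3 `C[C@@H](OCC1(c2ccccc2)CC(N)C1)c1cc(C(F)(F)F)cc(C(F)(F)F)c1` has not yet been measured. It is related to compound 1 by one change (hydrogen in place of (5-hydroxy-1H-1,2,4-triazol-3-yl)methyl on an amine nitrogen). The piece that leaves is the larger of the two and carries all the hydrogen-bond donors and acceptors of that group, so the expectation is a step toward a higher number in this assay, beyond the scatter but not dramatic, since the remainder of the shared core is unchanged. For compound 3 the expected inhibition constant is 3 nM, with a range from 0.8 nM to 15 nM. This estimate means a step of a 6.0-fold higher number from compound 1 to compound 3 (0.78 log units; beyond the scatter).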

Compound 3, inhibition constant: 0.02 nM
Beside the measured number, compound 3's estimate is 150-fold (2.18 log units) above it, and the stated range ends above it.
By their numbers in this assay, from the lowest: compound 3; then compounds 2 and 1 (each within the scatter of the next).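

Putting hydrogen in place of the (5-hydroxy-1H-1,2,4-triazol-3-yl)methyl group on the amine nitrogen gives a 25-fold lower number from compound 1 to compound 3 (1.40 log units; beyond the scatter) in this assay. This is the first single change shown at this position, and it shows that the number responds strongly to what sits on this nitrogen, which the gap between compound 1 and compound 2 could not reveal. The group that leaves, with its five-membered aromatic ring and all its hydrogen-bond donors and acceptors, is therefore not needed for a low number here, and the plain amino group of compound 3 does better, though no measured property of these compounds accounts for the difference.

With only this one pair, the compounds shown cannot tell whether the whole group costs binding or only part of it, such as the ring or the methyl link that joins it to the nitrogen. They also leave open whether a small group on the same nitrogen, such as a methyl or an acetyl group, would stay close to compound 3 or move back toward compound 1.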